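The compounds below may be only part of what the source reports. "The series", "measured", "known", "first", "only" and "open" are said of these compounds alone.

Measured so far:
- compound 1 `CCON=C1CCC(CN2CCN(c3nc(=O)c4cc(C(F)(F)F)cc([N+](=O)[O-])c4s3)CC2)CC1` — > 64 ug/mL
- compound 2 `CCON=C1CCC(CN2CCN(c3nc(=O)c4cc(C(F)(F)F)cc([N+](=O)[O-])c4s3)C[C@H]2C)CC1` — > 64 ug/mL

Compound 1 is the starting point. In an ADME assay on Vero cells (Chlorocebus sabaeus) for cytotoxicity (a lower number here means that less compound is tolerated, a higher number that more compound is tolerated), compound 1 gives > 64 ug/mL, and this is a limit of the assay, not a number. Compound 2 likewise reaches > 64 ug/mL in this assay, again a limit and not a number. The step from compound 1 to compound 2, a step that the two limits leave unreadable from compound 1 to compound 2, therefore cannot be sized in either direction.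

Compound 3 `CCON=C1CCC(CN2CCN(c3nc(=O)c4cc(C(F)(F)F)cc([N+](=O)[O-])c4s3)[C@H](C)C2)CC1` differs from compound 1 in one place: methyl in place of hydrogen on a saturated ring carbon. Within the data shown here, the only measured step that bears on this change is a step that the two limits leave unreadable from compound 1 to compound 2, which also adds a methyl on a saturated ring carbon of the same ring, and all that can be said of it rests on (the limit of > 64 ug/mL in this assay, at which 2 of the 2 values shown sit), where both of the values shown sit. No readable step is available, so no shift beyond the scatter can be predicted from the data in hand.

On that basis compound 3 is expected to give about 64 ug/mL in this assay, most likely again reported as a limit, within a range from 32 ug/mL to 128 ug/mL. The step from compound 1 to compound 3 is estimated at a number no higher from compound 1 to compound 3 (the limit leaves the size open), that is, none beyond the scatter.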

Compound 3, half-maximal cytotoxic concentration: > 64 ug/mL
Compound 3: a limit, no number (the forecaster's own chance of this, stated with the estimate: 85%); the middle value lies on the limit itself.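

Compound 3, like compound 1, ends at a limit in this assay, so no new step can be read from this result. All the values shown sit at that one limit: the limit of > 64 ug/mL in this assay, at which 3 of the 3 values shown sit. The compounds shown leave open whether a methyl in place of hydrogen on either saturated ring carbon shifts the read-out in this assay at all.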